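The source may report more compounds than this note shows. Statements on the series, on what has been measured and on what is new or still open speak of the compounds shown alone.

Measured so far:
- compound 1, `c1coc(CNc2nc(NCCCN3CCCC3)nc3ccccc23)c1`: 35300 nM
- compound 2, `Cc1cccc(N2CCN(CCCNc3nc(NCc4ccco4)c4ccccc4n3)CC2)c1C`: 930 nM

In a functional assay on DU-145 cells (Homo sapiens) for cytotoxicity, read by MTT assay, with a stated time of 2 days (a higher number here means a weaker inhibitor, a lower number a stronger inhibitor), compound 1 gives 35300 nM, the highest number of the two; compound 2 gives 930 nM, a gap well beyond the scatter. Compound 3, `CCCCCNc1nc(NCc2ccco2)c2ccccc2n1`, is not yet measured. It differs from compound 1 by ethyl in place of pyrrolidin-1-yl on a saturated chain carbon, three bonds along the chain from a nitrogen on an aromatic ring. For the measured compounds named here, no pair of measured compounds shows this change on its own, so the size of the step is uncertain. The expectation is a step of a 1.1-fold higher number from compound 1 to compound 3 (0.05 log units; within the scatter), small and in neither clear direction. Compound 3 is estimated at 40000 nM, between 10000 nM and 150000 nM.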

Compound 3, half-maximal inhibitory concentration: 11500 nM
Beside the measured number, compound 3's estimate is 3.5-fold (0.54 log units) above it; the measured number falls inside the stated range.
By their numbers in this assay, from the lowest: compound 2; then compound 3; then compound 1.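

In this assay, exchanging the 3-(pyrrolidin-1-yl)propyl group for pentyl gives a 3.1-fold lower number from compound 1 to compound 3 (0.49 log units; beyond the scatter). At this position, then, the pyrrolidine ring is not needed for cytotoxicity, and a plain carbon chain does modestly better here. No available evidence explains this step. As far as these compounds go, it remains open whether a shorter chain such as propyl would keep this gain, or whether a hydroxyl group or a simple dimethylamine at the chain end would lose it. A single step also leaves open whether the same exchange would act alike on a different core.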